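This account rests on a few compounds, and the source may have more. Where it says the series, first, only, none or still open, it means among the compounds named here.

The set begins with compound 1 `C=C1C[C@]23C[C@@]1(O)CC[C@H]2c1cc2c(C(=O)O)coc2c(C)c1[C@@H]3C(=O)O`, compound 2 `C=C1C[C@]23C[C@@]1(O)CC[C@H]2[C@@]12C=C[C@H](O)[C@@](C)(C(=O)O1)[C@H]2[C@@H]3C(=O)OC` and compound 3 `C=C1C[C@]23C[C@@]1(O)CC[C@H]2c1cc(Br)c(O/C=C/C(=O)OC)c(C)c1[C@@H]3C(=O)OC`, all tested in a functional assay on PSN1 cells (Homo sapiens) for cytotoxicity, read by luminescence and CellTiter-Glo, with a stated time of 24 h; on this read-out higher numbers stand for weaker inhibition and lower numbers for stronger inhibition. In this assay compound 1 reaches only a limit of the assay, > 10000 nM, and not a number. Compound 2 likewise reaches only a limit of the assay, > 10000 nM. Compound 3 also gives only a limit, > 10000 nM. So compound 2 stands where every other measured compound stands, at the limit of > 10000 nM in this assay, at which 3 of the 3 values shown sit. For the measured compounds named here, no compound here yields a number inside the working range of the assay, and no pair of measured compounds differs in a single place, so no measured step exists to compare against.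

The compound still to be measured is compound 4 `C=C1[C@@H](O)[C@]23C[C@@]1(O)CC[C@H]2[C@@]12C=C[C@H](O)[C@@](C)(C(=O)O1)[C@H]2[C@@H]3C(=O)OC`. It differs from compound 2 in one respect: hydroxy in place of hydrogen on a saturated ring carbon. Going by the values given here, because compound 2 gives only a limit, > 10000 nM, and nothing among the measured compounds points in any direction, no step beyond the usual scatter is expected in this assay from this change, neither towards stronger nor towards weaker inhibition. Compound 4 is therefore expected to give a value of about 20000 nM, most likely again reported only as a limit, within an expected range from 8000 nM to 50000 nM. That estimate corresponds to an expected step that the limit leaves unreadable from compound 2 to compound 4.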

Compound 4, half-maximal inhibitory concentration: > 10000 nM
Compound 4 was reported as a limit (the forecaster's own chance of this, stated with the estimate: 80%); the middle value lies beyond the limit too.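

For the compounds shown here, compound 2 and compound 4 both stop at a limit of this assay rather than at a number, so no step between them can be read: the limit of > 10000 nM in this assay, at which 4 of the 4 values shown sit.

The compounds shown leave open whether hydroxy in place of hydrogen on this saturated ring carbon changes inhibition at all, and what actual number any of the four compounds would give.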